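The source may hold more compounds than are shown below. What is called first, only, known or untested is meant among the compounds shown, and "the series" means these compounds.

Measured so far:
Compound 1 `COc1ccc2c(C3CC(c4ccncc4)=NO3)c[nH]c2c1`: 10500 nM
Compound 2 `c1ccc2c(C3CC(c4ccncc4)=NO3)c[nH]c2c1`: > 100000 nM

In a functional assay on PC-3 cells (Homo sapiens) for inhibition, read by MTT assay, with a stated time of 48 h (a higher number here means a weaker inhibitor, a lower number a stronger inhibitor), compound 1 gives 10500 nM. For compound 2 the assay gives only a limit, > 100000 nM, and no number; compound 2 therefore stands at the weak end of what is shown, resting on (the limit of > 100000 nM in this assay, at which 1 of the 2 values shown sits). For the measured compounds named here, the step of an at least 9.5-fold higher number from compound 1 to compound 2 (0.97 log units; beyond the scatter) is the only measured step available.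

Compound 3 `Fc1ccc2c(C3CC(c4ccncc4)=NO3)c[nH]c2c1` differs from compound 2 by fluoro in place of hydrogen on an aromatic carbon, placed on an aromatic carbon of a six-membered aromatic ring of carbon only, part of a fused system of two rings, meta to a fused ring and para to a fused ring. Going by the values given here, no measured step shows what fluoro does at this position; the measured step concerns methoxy, a different group. The expectation is a change of an at least 1.2-fold lower number from compound 2 to compound 3 (0.09 log units; that floor lies within the scatter), a step probably within the scatter, so compound 3 is estimated at 80000 nM, with a range from 20000 nM to 300000 nM, and a fair chance that the assay again reports only a limit.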

Compound 3, half-maximal inhibitory concentration: 12900 nM
Compound 3: middle estimate off by 6.2-fold (0.79 log units), on the high side; the whole stated range lies above it.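

In this assay, fluoro in place of hydrogen on this aromatic carbon gives an at least 7.7-fold lower number from compound 2 to compound 3 (0.88 log units; beyond the scatter), so methoxy is no longer the only group shown to do better than hydrogen here. The two groups also end up level, with a 1.2-fold higher number from compound 1 to compound 3 (0.09 log units; within the scatter), which means that a single fluorine atom does as much at this position as methoxy. Compound 2 has only a limit and not a number, so the step from hydrogen gives a floor and not a full size: the limit of > 100000 nM in this assay, at which 1 of the 3 values shown sits.

The compounds shown leave open whether almost any group on this carbon would serve or only these two, which a chloro group, an amine or a carboxylic acid here would help to settle. They also leave open whether fluoro would do the same on another carbon of this ring.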